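The compounds below may be only part of what the source reports. "The series", "measured", "known", "first", "only" and "open" are said of these compounds alone.

Measured so far in a functional assay on CHO-K1 cells for antagonist activity at adenosine receptor A1 (Homo sapiens), read by a beta-galactosidase reporter and cAMP accumulation, with stated times of 15 min and 6 h; on this read-out higher numbers stand for weaker inhibition and lower numbers for stronger inhibition:
- compound 1 `Cc1ccc(-c2nc(N)c3cc(C(C)c4ccccc4)sc3n2)o1` gives 439 nM
- compound 2 `CC(C)c1ccc(-c2nc(N)c3cc(Cc4ccccc4)sc3n2)o1` gives 283 nM
- compound 3 `N#Cc1ccc(-c2nc(N)c3cc(Cc4ccccc4)sc3n2)o1` gives 3160 nM

Compound 3 stands highest of the three numbers in this assay; compound 1 and compound 2 both sit well below it, and the two of them lie close to one another. For the measured compounds named here, the only single-point step among the measured compounds is an 11-fold higher number from compound 2 to compound 3 (1.05 log units; beyond the scatter), a large move toward weaker inhibition when a cyano group replaces an isopropyl group on the five-membered ring.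

Compound 4 `Nc1nc(-c2cnco2)nc2sc(Cc3ccccc3)cc12` is not yet measured. It differs from compound 3 in one place: 1,3-oxazol-5-yl in place of 5-cyanofuran-2-yl on an aromatic carbon. Going by the values given here, no measured pair shows this exact exchange. The step that bears on it is an 11-fold higher number from compound 2 to compound 3 (1.05 log units; beyond the scatter), which ties the weakest number of the set to the cyano-bearing furan; compound 4 sheds that group, but the ring itself also changes, and nothing in the set shows what a 1,3-oxazol-5-yl does at this position. Some return toward the numbers of compound 1 and compound 2 is expected, with wide uncertainty.

For compound 4 in this assay the expected value is 900 nM, in the range 200 nM to 4000 nM. This corresponds to an expected step of a 3.5-fold lower number from compound 3 to compound 4 (0.55 log units; beyond the scatter).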

Compound 4, inhibition constant: 106 nM
For compound 4 the middle estimate is 8.5-fold (0.93 log units) above the measured one; measured number outside the range, below it.
By their numbers in this assay, from the lowest: compound 4; then compounds 2 and 1 (each within the scatter of the next); then compound 3.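

In this assay, the group on the aromatic carbon between two ring nitrogen atoms can move the number much further than the two furans alone indicated: 1,3-oxazol-5-yl in place of 5-cyanofuran-2-yl gives a 30-fold lower number from compound 3 to compound 4 (1.47 log units; beyond the scatter). A substituted furan is therefore not needed at this position for a low number, since the same ring also compares favourably with the isopropyl-bearing furan, with a 2.7-fold lower number from compound 2 to compound 4 (0.43 log units; beyond the scatter), and does so with fewer heavy atoms and an added ring hetero atom. No measurement at hand accounts for either step.

From the compounds shown here alone, it remains open whether these steps follow from the change of ring or from the loss of the furan's substituent; an unsubstituted furan-2-yl and a methyl-bearing 1,3-oxazol-5-yl would separate the two. Also open, going by these compounds, are whether an amine or a carboxylic acid on the oxazole would keep the number near that of compound 4, and whether the oxazole would give a similar step on the 1-phenylethyl-bearing core of compound 1.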